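Amine end-group swap at the chain terminus

The source may hold more compounds than are shown below. What is called first, only, known or untested is meant among the compounds shown, and "the series" means these compounds.

Among the measured compounds shown here, compound 2 `O=c1cc(-c2ccccc2)oc2ccc(OCCCCCCN3CCNC(CCO)C3)cc12` holds the lowest number so far in an assay on isolated protein (Cavia porcellus) with Sigma non-opioid intracellular receptor 1 (Homo sapiens) as the target, read by radioligand binding (a higher number here means a weaker inhibitor, a lower number a stronger inhibitor), giving 94 nM; compound 1 `CN(C)CCCCCCCCCOc1ccc2oc(-c3ccccc3)cc(=O)c2c1` gives 202 nM. For the measured compounds named here, the single measured step, a 2.1-fold lower number from compound 1 to compound 2 (0.33 log units; beyond the scatter), touched the same chain end but exchanged the whole amine. Compound 3 `O=c1cc(-c2ccccc2)oc2ccc(OCCCCCCN3CCNCC3c3ncccn3)cc12` differs by 2-(pyrimidin-2-yl)piperazin-1-yl in place of 3-(2-hydroxyethyl)piperazin-1-yl on a saturated chain carbon, six bonds along the chain from an oxygen on an aromatic ring, so the piperazine stays and only its substituent changes. Going by the values given here, no measured step tests such a substituent change, so no shift beyond the scatter is expected in this assay. For compound 3 the expected value is 100 nM, range 35 nM to 300 nM, which as an estimated step means a 1.1-fold higher number from compound 2 to compound 3 (0.03 log units; within the scatter).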

Compound 3, half-maximal inhibitory concentration: 14200 nM
Compound 3: the middle estimate sits 140-fold (2.15 log units) below what was measured, and the stated range ends below it.
By their numbers in this assay, from the lowest: compound 2; then compound 1; then compound 3.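

Keeping the piperazine does not preserve binding at this chain end: in this assay, 2-(pyrimidin-2-yl)piperazin-1-yl in place of 3-(2-hydroxyethyl)piperazin-1-yl gives a 150-fold higher number from compound 2 to compound 3 (2.18 log units; beyond the scatter) and is the largest change seen so far. The same group also compares poorly with the 3-(dimethylamino)propyl end, with a 70-fold higher number from compound 1 to compound 3 (1.85 log units; beyond the scatter) in the same assay. No available evidence explains this loss.

Still open, going by these compounds, is whether the loss follows the pyrimidin-2-yl ring itself or the substituent's place on the piperazine. A 3-(pyrimidin-2-yl)piperazin-1-yl or 2-phenylpiperazin-1-yl end would separate these two readings.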